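Changing the Aryl Group on the Double-Bonded Carbon

The source may report more compounds than this note shows. Statements on the series, on what has been measured and on what is new or still open speak of the compounds shown alone.

Compound 1, `O=C(CSc1nnc(-c2ccncc2)n1-c1ccccc1)N/N=C/c1ccc([N+](=O)[O-])cc1`: 15900 nM
Compound 2, `O=C(CSc1nnc(-c2ccncc2)n1-c1ccccc1)N/N=C/c1ccccc1F`: 15200 nM

These two compounds share one core and differ only in the aryl group attached to a carbon with a double bond to nitrogen. In a functional assay on HepG2 cells (Homo sapiens) for inhibition, read by MTT assay, with a stated time of 48 h (on this read-out lower numbers stand for stronger inhibition and higher numbers for weaker inhibition), compound 1 gives 15900 nM. In this assay compound 2 gives 15200 nM; this is the lower of the two numbers, but the step of a 1.0-fold lower number from compound 1 to compound 2 (0.02 log units; within the scatter) is within the scatter, so the two compounds cannot be told apart. Compound 3, `O=C(CSc1nnc(-c2ccncc2)n1-c1ccccc1)N/N=C/c1cc(Br)cc(Br)c1O`, has not yet been measured. It differs from compound 2 in one place: 3,5-dibromo-2-hydroxyphenyl in place of 2-fluorophenyl on a carbon with a double bond to nitrogen. For the measured compounds named here, the only measured step that bears on this change, a 1.0-fold lower number from compound 1 to compound 2 (0.02 log units; within the scatter), varied the same aryl group and produced nothing beyond the scatter. For compound 3 in this assay no step beyond the scatter is therefore expected, and the step of a 1.1-fold lower number from compound 2 to compound 3 (0.04 log units; within the scatter) is expected to be small. Compound 3 is estimated at 14000 nM, with a range from 5000 nM to 40000 nM.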

Compound 3, half-maximal inhibitory concentration: 7590 nM
The estimate for compound 3 lay 1.8-fold (0.27 log units) above the measured number; the measured number falls inside the stated range.
By their numbers in this assay, from the lowest: compounds 3, 2 and 1 (each within the scatter of the next, the first and the last beyond it).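

In this assay, changing the aryl group on the carbon with a double bond to nitrogen does give a step beyond the scatter, a 2.1-fold lower number from compound 1 to compound 3 (0.32 log units; beyond the scatter), although a modest one, so the earlier pair's lack of separation does not hold for every aryl group here. The other step, a 2.0-fold lower number from compound 2 to compound 3 (0.30 log units; within the scatter), stays within the scatter, so compound 3 cannot be told apart from compound 2. No measurement shown here explains the difference between compound 1 and compound 3.

The 3,5-dibromo-2-hydroxyphenyl group brings in bromine and a hydroxyl group together, so these compounds cannot show whether either one alone goes with the step. Also open, going by these compounds, is what a plain phenyl ring, or an aryl ring carrying an amine or a carboxylic acid, would give at this place.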